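Fluoro moved to the other phenyl: expected tolerance

The source may hold more compounds than are shown below. What is called first, only, known or untested is meant among the compounds shown, and "the series" means these compounds.

Measured so far in a functional assay on HeLa cells (Homo sapiens) for cytotoxicity, read by MTT assay, with a stated time of 2 days; a lower number here means that less compound is tolerated, a higher number that more compound is tolerated:
compound 1 `CC(=O)c1cc(-c2ccccc2)cc2cc(-c3ccccc3)[nH]c12` gives > 100000 nM
compound 2 `CC(=O)c1cc(-c2ccc(F)cc2)cc2cc(-c3ccccc3)[nH]c12` gives 38000 nM
compound 3 `COc1ccc(-c2cc(C(C)=O)c3[nH]c(-c4ccccc4)cc3c2)cc1` gives 15500 nM

The value of compound 1 is a limit of this assay and not a number. Compound 1 therefore stands at the limit of > 100000 nM in this assay, at which 1 of the 3 values shown sits, the top of the shown range.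

Compound 4 `CC(=O)c1cc(-c2ccccc2)cc2cc(-c3ccc(F)cc3)[nH]c12` differs from compound 1 by fluoro in place of hydrogen on an aromatic carbon, on the phenyl that carries no substituent in compound 2 or compound 3. The measured steps all concern the other phenyl: an at least 2.6-fold lower number from compound 1 to compound 2 (0.42 log units; beyond the scatter), an at least 6.4-fold lower number from compound 1 to compound 3 (0.80 log units; beyond the scatter) and a 2.5-fold lower number from compound 2 to compound 3 (0.39 log units; beyond the scatter). The fluoro step is the closest analogue of the change to compound 4, though it sits on a different ring, so its size is taken as a rough guide with wide uncertainty; a step of similar size downward is expected in this assay, and a value at the limit again is not excluded.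

Compound 4 is expected to give 50000 nM, with a range of 20000 nM to 150000 nM. That estimate means an expected step of an at least 2.0-fold lower number from compound 1 to compound 4 (0.30 log units; that floor lies within the scatter).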

Compound 4, concentration lethal to 50% of the cells: > 100000 nM
Compound 4 ended at the assay's limit; the forecaster's own chance of this, stated with the estimate: 35%; middle value at least 2.0-fold (0.30 log units) from the limit.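

Compound 1 and compound 4 both sit at the limit of this assay, so no step between the two can be read: the limit of > 100000 nM in this assay, at which 2 of the 4 values shown sit.

The compounds shown leave open whether phenyl to 4-fluorophenyl on this ring changes tolerance at all, and where either compound truly stands beyond that limit.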